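Dialkylamino in place of dimethoxy-alkylamino on the shared core

The source may hold more compounds than are shown below. What is called first, only, known or untested is meant among the compounds shown, and "the series" means these compounds.

Measured compounds:
- compound 1, `COCC(COC)Nc1nc(C)nc2c(-c3ccc(OC)cc3C)c(C)nn12`: 9.7 nM
- compound 2, `CCC(CC)Nc1nc(C)nc2c(-c3ccc(OC)cc3)c(C)nn12`: 3.8 nM
- compound 3, `CCCN(c1nc(C)nc2c(-c3c(C)cc(OC)cc3OC)c(C)nn12)C1CC1`: 1.48 nM

In an assay on cell membranes for displacement of a labelled ligand from corticotropin-releasing factor receptor 1 (Rattus norvegicus) (on this read-out higher numbers stand for weaker inhibition and lower numbers for stronger inhibition), compound 1 gives 9.7 nM, the highest of the three numbers. Compound 2 sits nearest, with a lower number beyond the scatter, and compound 3 gives the lowest number of the set, further still from compound 1. Compound 2 and compound 3 each carry an amino group made only of carbon chains, while compound 1 carries the ether-bearing group; the aryl groups differ as well, so the three values show no single change on its own.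

Compound 4, `CCCCN(CC)c1nc(C)nc2c(-c3ccc(OC)cc3C)c(C)nn12`, is not yet measured. It differs from compound 1 in one place: butyl(ethyl)amino in place of (2-methoxy-1-(methoxymethyl)ethyl)amino on an aromatic carbon. Going by the values given here, no step between measured compounds tracks this change directly. Among the compounds with values here, the values of compound 2 and compound 3, both lower than that of compound 1, are the only guide here, and both carry amino groups without ether oxygens.

On that basis the step of a 3.2-fold lower number from compound 1 to compound 4 (0.51 log units; beyond the scatter) is expected to run downward, beyond the scatter. For compound 4 the estimate in this assay is 3 nM, with a range from 1 nM to 10 nM.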

Compound 4, half-maximal inhibitory concentration: 2.3 nM
Estimate against measurement, compound 4: 1.3-fold (0.12 log units) above, within the range that was stated.
By their numbers in this assay, from the lowest: compounds 3, 4 and 2 (each within the scatter of the next, the first and the last beyond it); then compound 1.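

In this assay, going by these compounds alone, with the aryl group and the rest of the shared core held fixed, butyl(ethyl)amino in place of (2-methoxy-1-(methoxymethyl)ethyl)amino gives a 4.2-fold lower number from compound 1 to compound 4 (0.63 log units; beyond the scatter), so this position on the carbon between two ring nitrogen atoms can now be read on its own, which the earlier compounds, with their differing aryl groups, did not allow. Within the data shown here, the single step changes several things at once: the entering group has 0 hydrogen-bond donors and 1 hydrogen-bond acceptor against 1 donor and 3 acceptors in the leaving group, and it has two chains on the nitrogen instead of one branched chain, so the step cannot be assigned to any one of these differences. No measurement at hand ties the step to a cause.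

On these data alone, whether the ether oxygens or the amine hydrogen matter more remains open, and bis(2-methoxyethyl)amino on the core and aryl group of compound 4 would bear directly on that question. Among these compounds, also open is whether the step holds with other aryl groups, such as the one in compound 3, since it has been read only with the aryl group of compound 1.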